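The source may report more compounds than this note shows. Statements on the series, on what has been measured and on what is new or still open speak of the compounds shown alone.

Compound 1 `O=C(N/N=C/c1cc2ccccc2nc1Cl)c1cc2cc(Br)ccc2oc1=O` was examined in a functional assay on HepG2 cells (Homo sapiens) for antiproliferative activity, read by fluorescence and resazurin assay, with a stated time of 48 h (a lower number here means a stronger inhibitor, a higher number a weaker inhibitor), and there compound 1 gives 9420 nM. Compound 2 `O=C(N/N=C/c1ccncc1)c1cc2cc(Br)ccc2oc1=O` rests on another core; the difference between the two cores is not broken down here. In this assay compound 2 gives 4890 nM. Compound 3 `O=C(N/N=C/c1ccncc1)c1cc2cc([N+](=O)[O-])ccc2oc1=O` differs from compound 2 by nitro in place of bromo on an aromatic carbon, and in this assay compound 3 gives 15800 nM, so that change made a 3.2-fold higher number from compound 2 to compound 3 (0.51 log units; beyond the scatter). Compound 4 `O=C(N/N=C/c1cc2ccccc2nc1Cl)c1cc2cc([N+](=O)[O-])ccc2oc1=O` has not yet been measured; it differs from compound 1 by nitro in place of bromo on an aromatic carbon, the same change at the same place, occurring twice among these compounds. Because the earlier step was a 3.2-fold higher number from compound 2 to compound 3 (0.51 log units; beyond the scatter), a step of similar size is expected here, estimated as a 2.8-fold higher number from compound 1 to compound 4 (0.44 log units; beyond the scatter). Compound 4 is therefore expected at about 26000 nM, most likely between 9000 nM and 75000 nM.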

Compound 4, half-maximal inhibitory concentration: 22800 nM
For compound 4 the middle estimate is 1.1-fold (0.06 log units) above the measured one; the measured number falls inside the stated range.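

In this assay, nitro in place of bromo gave a 2.4-fold higher number from compound 1 to compound 4 (0.38 log units; beyond the scatter), so the number moved in the same direction on the core of compound 1 as on the core of compound 2. The two steps also agree in size: the same change on two cores in this assay, a 3.2-fold higher number (0.51 log units; beyond the scatter) from compound 2 to compound 3 and a 2.4-fold higher number (0.38 log units; beyond the scatter) from compound 1 to compound 4, 1.3-fold (0.13 log units) apart, within the scatter of two such steps. The change therefore carried over between these two cores in this assay, but two cores are a small sample, and this does not show why nitro gives weaker inhibition or that the step would hold on a further core.

The compounds shown leave open what other groups on that aromatic carbon would do, such as an amine, a carboxylic acid or a methoxy group.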